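Ethoxy for isopropyl on the fused five-membered ring

The source may hold more compounds than are shown below. What is called first, only, known or untested is meant among the compounds shown, and "the series" means these compounds.

Three compounds share one core and were compared in a functional assay on CHO cells for antagonist activity at Orexin/Hypocretin receptor type 1 (Homo sapiens), read by FLIPR and calcium flux; a higher number here means a weaker inhibitor, a lower number a stronger inhibitor. Compound 1 `CCc1nc(C(F)(F)F)c2n1CCN([C@@H](C(=O)NC)c1ccccc1)[C@H]2CCc1ccc(C(F)(F)F)cc1` gives 1070 nM. Compound 2 `CNC(=O)[C@@H](c1ccccc1)N1CCn2c(COC)nc(Cl)c2[C@@H]1CCc1ccc(C(F)(F)F)cc1` gives 1650 nM. Compound 3 `CCc1nc(C(C)C)c2n1CCN([C@@H](C(=O)NC)c1ccccc1)C2CCc1ccc(C(F)(F)F)cc1` gives 10000 nM, the highest of the three numbers, and its distance to compound 2 and to compound 1 lies beyond the scatter. Compound 4 `CCOc1nc(CC)n2c1C(CCc1ccc(C(F)(F)F)cc1)N([C@@H](C(=O)NC)c1ccccc1)CC2` differs from compound 3 in one place: ethoxy in place of isopropyl on an aromatic carbon. Within the data shown here, no pair of measured compounds isolates this exchange, so the step has no direct precedent. Since compound 3 gives 10000 nM while the other two sit well lower, a move downward is expected, and the step from compound 3 to compound 4 is estimated at a 2.5-fold lower number from compound 3 to compound 4 (0.40 log units; beyond the scatter). Compound 4 is therefore expected to give 4000 nM, with a range from 1000 nM to 16000 nM.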

Compound 4, half-maximal inhibitory concentration: 3980 nM
Compound 4: the middle estimate sits 1.0-fold (0.00 log units) above what was measured, and the stated range covers the measured number.
By their numbers in this assay, from the lowest: compounds 1 and 2 (each within the scatter of the next); then compound 4; then compound 3.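

At this aromatic carbon, next to the ring nitrogen, ethoxy in place of isopropyl keeps the same heavy-atom count but brings in an oxygen and a hydrogen-bond acceptor. In this assay this exchange gives a modest step (a 2.5-fold lower number from compound 3 to compound 4 (0.40 log units; beyond the scatter)), so the number at this position does respond to the group it carries. Nothing measured here explains the step.

Going by these compounds, whether the step follows from the oxygen itself remains open. So does how a methoxy group, an amine or a longer alkoxy chain would read at this carbon.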